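The source may report more compounds than this note shows. Statements on the series, on what has been measured and on what is new or still open speak of the compounds shown alone.

Measured in a functional assay on MCF7 cells (Homo sapiens) for antiproliferative activity, read by MTT assay, with a stated time of 72 h; a higher number here means a weaker inhibitor, a lower number a stronger inhibitor:
Compound 1 `O=C1O/C(=C\Cn2cc(-c3ccc(Br)cc3)nn2)C(OCc2ccccc2)=C1OCc1ccccc1`: > 100000 nM, which is a limit and not a number.
Compound 2 `CCCCCc1ccc(-c2cn(C[C@H](O)[C@H]3OC(=O)C(OCc4ccccc4)=C3OCc3ccccc3)nn2)cc1`: 9010 nM
Compound 3 `COc1ccc(-c2cn(C/C=C3\OC(=O)C(OCc4ccccc4)=C3OCc3ccccc3)nn2)cc1`: 39100 nM

Of the two actual numbers, compound 2 has the lower, and the gap to compound 3 lies beyond the scatter. Compound 4 `O=C1O[C@H]([C@@H](O)Cn2cc(C3CC3)nn2)C(OCc2ccccc2)=C1OCc1ccccc1` differs from compound 2 in one place, with cyclopropyl in place of 4-pentylphenyl on an aromatic carbon. Within the data shown here, only one measured step touches this aromatic carbon's substituent, and only indirectly: an at least 2.5-fold lower number from compound 1 to compound 3 (0.40 log units; beyond the scatter), with methoxy in place of bromo. That step rests on (the limit of > 100000 nM in this assay, at which 1 of the 3 values shown sits). Among the measured compounds shown here, no measured step removes the aromatic ring, so the guide is loose. A clear move towards a higher number in this assay is expected, and the expected change is a 5.0-fold higher number from compound 2 to compound 4 (0.70 log units; beyond the scatter). For compound 4 the estimate is 45000 nM, with an expected range of 15000 nM to 100000 nM.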

Compound 4, half-maximal inhibitory concentration: 25900 nM
Estimate against measurement, compound 4: 1.7-fold (0.24 log units) above; measured number inside the range.
By their numbers in this assay, from the lowest: compound 2; then compounds 4 and 3 (each within the scatter of the next). At a limit, above all of these: compound 1.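

In this assay, putting cyclopropyl in place of 4-pentylphenyl on the aromatic carbon gives a 2.9-fold higher number from compound 2 to compound 4 (0.46 log units; beyond the scatter), so this position's substituent affects the number even when the two compounds share the rest of their structure. Compound 4 shows that a measured value remains once the six-membered aromatic ring has gone. The earlier step kept that ring and starts from compound 1, whose value is a limit and not a number: the limit of > 100000 nM in this assay, at which 1 of the 4 values shown sits.

Still open, as far as these compounds go, is how a plain phenyl, a pentyl chain without the ring or an amine at this position would compare with these two groups.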